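The source may report more compounds than this note shows. Statements on the series, on what has been measured and on what is new or still open speak of the compounds shown alone.

Measured compounds:
compound 1 `CC(O)Cn1c([N+](=O)[O-])cnc1/C=C/c1ccccc1F` with 1410 nM
compound 2 `Cc1ccc(/C=C/c2ncc([N+](=O)[O-])n2CC(C)O)cc1` with 860 nM
compound 3 `CC(O)Cn1c([N+](=O)[O-])cnc1/C=C/c1c(F)cccc1Cl` with 710 nM

In an ADME assay on cells (Macrophage, Homo sapiens) for cytotoxicity, read by MTT assay, with a stated time of 24 h (on this read-out higher numbers stand for lower toxicity in this test and lower numbers for higher toxicity in this test), compound 1 shows the largest of the three numbers, yet neither neighbour is separated from it beyond the scatter: a 1.6-fold lower number from compound 1 to compound 2 (0.21 log units; within the scatter) and a 2.0-fold lower number from compound 1 to compound 3 (0.30 log units; within the scatter). Compound 4 `CC(O)Cn1c([N+](=O)[O-])cnc1/C=C/c1ccccc1[N+](=O)[O-]` differs from compound 1 by nitro in place of fluoro on an aromatic carbon, on an aromatic carbon of a six-membered aromatic ring of carbon only, ortho to a large group. Both measured steps alter the same aromatic ring, one by exchanging the whole substituent, one by adding a group, and both stay within the scatter, so compound 4 is expected to show no step beyond the scatter, a 1.2-fold lower number from compound 1 to compound 4 (0.07 log units; within the scatter). Compound 4 is therefore estimated at 1200 nM, with a range from 500 nM to 3000 nM.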

Compound 4, half-maximal cytotoxic concentration: 1090 nM
Beside the measured number, compound 4's estimate is 1.1-fold (0.04 log units) above it; measured number inside the range.
By their numbers in this assay, from the lowest: compounds 3, 2, 4 and 1 (each within the scatter of the next).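

In this assay, the exchange of fluoro for nitro on the aromatic carbon ortho to a large group comes with a 1.3-fold lower number from compound 1 to compound 4 (0.11 log units; within the scatter) and stays within the scatter. This position therefore accepts 3 heavy atoms and 2 hydrogen-bond acceptors in place of a single fluorine without a step beyond the scatter. Nothing measured here bears on why this exchange gives so small a step. Going by these compounds, whether an amine or a carboxylic acid on this carbon would also stay within the scatter remains open. So does whether a change outside this aromatic ring would move the number further.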